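The compounds below may be only part of what the source reports. "The series", "measured", "known", "first", "only" and "open" are said of these compounds alone.

Compound 1 `Cc1cccc2sc(NC(=O)COc3ccc(/C=C4\SC(=O)NC4=O)cc3)nc12` in a functional assay on PC-3 cells (Homo sapiens) for inhibition; a higher number here means a weaker inhibitor of growth, a lower number a stronger inhibitor of growth: > 100000 nM, which is a limit of the assay rather than a number.
Compound 2 `Cc1cccc(NC(=O)COc2ccc(/C=C3\SC(=O)NC3=O)cc2)n1` in this assay: 58300 nM.

Among the measured compounds shown here, compound 2 is the only one of the pair to give an actual number in this assay. Compound 1 sits at the limit of > 100000 nM in this assay, at which 1 of the 2 values shown sits. Compound 3 `O=C(COc1ccc(/C=C2\SC(=O)NC2=O)cc1)Nc1ccc([N+](=O)[O-])cc1` differs from compound 2 by 4-nitrophenyl in place of 6-methylpyridin-2-yl on an amide-type nitrogen. For the measured compounds named here, no measured step of this kind exists here, so the change from compound 2 to compound 3 is expected to stay within the usual scatter, with no clear direction: a 1.1-fold lower number from compound 2 to compound 3 (0.03 log units; within the scatter). Compound 3 is therefore estimated at 55000 nM, within a range from 18000 nM to 170000 nM.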

Compound 3, concentration for 50% growth inhibition: > 100000 nM
Compound 3 ended at the assay's limit; the forecaster's own chance of this, stated with the estimate: 35%; at least 1.8-fold (0.25 log units) between middle value and limit.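

Among the compounds shown here, on the amide-type nitrogen, 4-nitrophenyl in place of 6-methylpyridin-2-yl gives the first step that can be read in this assay, an at least 1.7-fold higher number from compound 2 to compound 3 (0.23 log units; that floor lies within the scatter). Going by these compounds, the result for compound 3 is a limit of the assay and not a number, so the true size of this step stays unknown. Compound 1 and compound 3 stand at the same limit, which leaves only one real number in the set: the limit of > 100000 nM in this assay, at which 2 of the 3 values shown sit.

On these data alone, it remains open whether any group on this nitrogen can give a clearly lower number than compound 2, at 58300 nM. A phenyl ring carrying an amine or a carboxylic acid in place of 4-nitrophenyl would help test this.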